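A few compounds are considered here, and "the series" means these few. Any claim that something is new, unique, unknown or untested is made for them only; others in the source may bear on it.

Of the compounds shown here, two have been measured in a functional assay on MDA-MB-231 cells (Homo sapiens) for inhibition, read by sulforhodamine B assay, with a stated time of 48 h; on this read-out higher numbers stand for lower toxicity in this test and lower numbers for higher toxicity in this test. Compound 1 `COc1cc(-c2cc(/C=C/C(=O)c3ccc(N)cc3)[nH]n2)cc(OC)c1OC` gives 47500 nM. Compound 2 `COc1ccc(-c2cc(/C=C/C(=O)c3ccc(OC)c(OC)c3)[nH]n2)cc1` gives 30000 nM in this assay. Compound 1 holds the higher of the two numbers, but the values of compound 1 and compound 2 lie within the scatter of each other, so no order between them can be read from the data.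

Compound 3 `COc1cc(-c2cc(/C=C/C(=O)c3ccc(Cl)c(Cl)c3)[nH]n2)cc(OC)c1OC` has not yet been measured in this assay. It differs from compound 1 in a single place: 3,4-dichlorophenyl in place of 4-aminophenyl on a carbonyl carbon. The 3,4-dichlorophenyl thus takes the position of the 4-aminophenyl on the carbonyl carbon whose other neighbour is a double-bonded chain carbon. Among the measured compounds shown here, no measured pair shows this kind of change, so nothing in the data fixes its size; the expectation rests on the measured values of compound 1 alone. Compound 3 is expected to shift in this assay by a 1.9-fold lower number from compound 1 to compound 3 (0.28 log units; within the scatter), a modest move toward a lower number that may not clear the scatter. The estimate for compound 3 in this assay is 25000 nM, with a range from 8000 nM to 80000 nM.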

Compound 3, concentration lethal to 50% of the cells: > 100000 nM
Compound 3 ended at the assay's limit; the forecaster's own chance of this, stated with the estimate: 10%; at least 4.0-fold (0.60 log units) between middle value and limit.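

On the carbonyl carbon whose other neighbour is a double-bonded chain carbon, 3,4-dichlorophenyl in place of 4-aminophenyl gives in this assay an at least 2.1-fold higher number from compound 1 to compound 3 (0.32 log units; beyond the scatter), so the group at this position does change the read-out, and the move runs toward lower toxicity in this test. Among the compounds shown here, compound 3 gives > 100000 nM, which is a limit of the assay and not a number, so the step fixes a direction and a minimum but no full size: the limit of > 100000 nM in this assay, at which 1 of the 3 values shown sits. Before this result the series held no step between compounds differing in one place, which makes this the first reading of any single position.

One pair cannot show which part of the change carries the step, the loss of the amine or the entry of the two chlorine atoms; a plain phenyl or a 4-chlorophenyl on the same carbonyl carbon would begin to separate the two. Also open, as far as these compounds go, is whether a carboxylic acid at this place would move the read-out the same way, and whether this change would give a similar step on the core of compound 2.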